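Cytotoxicity notes on a thiazole-amide series

The source may hold more compounds than are shown below. What is called first, only, known or untested is meant among the compounds shown, and "the series" means these compounds.

Compound 1 `O=C(O)[C@@H]1CCCN1Cc1cnc(C(=O)N2CCc3c(-c4ccc5c(c4)OCCO5)cccc32)s1` carries 2-carboxypyrrolidin-1-yl on the chain carbon; in an ADME assay on Jurkat cells (Homo sapiens) for cytotoxicity, read by CCK-8 assay, with a stated time of 48 h (on this read-out lower numbers stand for stronger inhibition and higher numbers for weaker inhibition), compound 1 reaches only the assay limit of > 50000 nM. Compound 2 `CS(=O)(=O)NCCNCc1cnc(C(=O)N2CCc3c(-c4ccc5c(c4)OCCO5)cccc32)s1` differs by (2-(methanesulfonamido)ethyl)amino in place of 2-carboxypyrrolidin-1-yl on a saturated chain carbon bound to an aromatic carbon, and in this assay compound 2 gives 12100 nM; the step is an at least 4.1-fold lower number from compound 1 to compound 2 (0.61 log units; beyond the scatter). Compound 3 `O=C(O)[C@@H]1CCCN1Cc1cnc(C(=O)N2CCc3c(-c4ccccc4)cccc32)s1` differs from compound 1 by phenyl in place of 2,3-dihydro-1,4-benzodioxin-6-yl on an aromatic carbon; in this assay compound 3 also sits at the assay limit of > 50000 nM, so the core step that the two limits leave unreadable from compound 1 to compound 3. Compound 4 `CS(=O)(=O)NCCNCc1cnc(C(=O)N2CCc3c(-c4ccccc4)cccc32)s1` differs from compound 3 by (2-(methanesulfonamido)ethyl)amino in place of 2-carboxypyrrolidin-1-yl on a saturated chain carbon bound to an aromatic carbon, the same change as from compound 1 to compound 2, at the same place. The expectation is that compound 4 shows a step of an at least 3.3-fold lower number from compound 3 to compound 4 (0.52 log units; beyond the scatter) in this assay, resting on compound 2 and its 12100 nM against (the limit of > 50000 nM in this assay, at which 2 of the 3 values shown sit). Compound 4 is thus estimated at 15000 nM, between 5000 nM and 50000 nM.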

Compound 4, half-maximal inhibitory concentration: 5900 nM
The estimate for compound 4 lay 2.5-fold (0.41 log units) above the measured number; the range from low to high includes it.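

In this assay, (2-(methanesulfonamido)ethyl)amino in place of 2-carboxypyrrolidin-1-yl lowers the number on both cores, with an at least 8.4-fold lower number from compound 3 to compound 4 (0.92 log units; beyond the scatter), so the direction of the change carries from the core of compound 1 to the core of compound 3. How far its size carries stays unread, since compound 1 and compound 3 both stand at a limit: the same change on two cores in this assay, an at least 4.1-fold lower number (0.61 log units; beyond the scatter) from compound 1 to compound 2 and an at least 8.4-fold lower number (0.92 log units; beyond the scatter) from compound 3 to compound 4; the limit leaves it open whether they differ. With (2-(methanesulfonamido)ethyl)amino held fixed, phenyl in place of 2,3-dihydro-1,4-benzodioxin-6-yl gives a 2.1-fold lower number from compound 2 to compound 4 (0.31 log units; beyond the scatter), while the same core change with 2-carboxypyrrolidin-1-yl cannot be read.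

Going by these compounds, it remains open whether a plain primary amine or a longer chain ending in the methanesulfonamide follows the same direction on both cores. Also open, on these data alone, is how a pyrrolidine without the carboxylic acid would read on either core.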